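Removing the bromine from the shared core

The compounds below may be only part of what the source reports. "The series", "measured", "known", "first", "only" and "open" are said of these compounds alone.

Compound 2 `CC(=O)O[C@@H]1OC(=O)[C@](Br)(C(C)=O)[C@@H]1C` is the weaker of the two compounds measured here in a functional assay on MCF7 cells (Homo sapiens) for cytotoxicity, read by MTT assay; on this read-out lower numbers stand for stronger inhibition and higher numbers for weaker inhibition. In this assay compound 2 gives 17000 nM, whereas compound 1 `CC(=O)O[C@@H]1OC(=O)[C@](C)(C(C)=O)[C@@H]1C` gives 6000 nM. Going by the values given here, the only measured step, a 2.8-fold higher number from compound 1 to compound 2 (0.45 log units; beyond the scatter), shows that putting bromo where methyl stood on the saturated ring carbon raised the number. Compound 3 `CC(=O)O[C@@H]1OC(=O)[C@@H](C(C)=O)[C@@H]1C` goes one way further: hydrogen in place of bromo on a saturated ring carbon. Among the compounds with values here, no measured pair shows hydrogen taking the place of bromo, so the step from compound 1 to compound 2 is the only guide, and it points to the bromo compound being the weakest of the three. Compound 3 is therefore expected to fall back towards the value of compound 1, with an estimated step of a 1.9-fold lower number from compound 2 to compound 3 (0.28 log units; within the scatter) in this assay. For compound 3 the estimate is 9000 nM, with a range from 3500 nM to 25000 nM.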

Compound 3, half-maximal inhibitory concentration: > 50000 nM
Compound 3: no number, only a limit; the forecaster's own chance of this, stated with the estimate: 10%; middle value at least 5.5-fold (0.74 log units) away from the limit.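

Compound 3 gives a limit of the assay rather than a number in this assay: the limit of > 50000 nM in this assay, at which 1 of the 3 values shown sits. Even so, hydrogen in place of bromo gives an at least 2.9-fold higher number from compound 2 to compound 3 (0.46 log units; beyond the scatter) and hydrogen in place of methyl gives an at least 8.3-fold higher number from compound 1 to compound 3 (0.92 log units; beyond the scatter). The earlier pair showed only that swapping methyl for bromo on this saturated ring carbon changes the number modestly, whereas these steps show that the compound with hydrogen there, carrying neither group, is the weakest of the three, so the order runs methyl, bromo, hydrogen.

Going by these compounds, how far compound 3 truly lies beyond its limit stays unknown, so the full size of both steps is open. Also open, on these data alone, is how other groups on this carbon, such as an ethyl group, a hydroxyl or an amine, would compare with methyl and bromo.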